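This account rests on a few compounds, and the source may have more. Where it says the series, first, only, none or still open, it means among the compounds named here.

Measured in a functional assay on NCI-H1975 cells (Homo sapiens) for antiproliferative activity, read by MTT assay, with a stated time of 72 h; a lower number here means a stronger inhibitor, a higher number a weaker inhibitor:

- Compound 1 `CN1CCN(c2ccc(Nc3ncc4nc(Nc5ccccc5)n([C@H]5CCN(C(=O)OC(C)(C)C)C5)c4n3)cc2)CC1`: "not determined" (no result reported)
- Compound 2 `CN1CCN(c2ccc(Nc3ncc4nc(Nc5ccccc5)n([C@H]5CCNC5)c4n3)cc2)CC1`: "not determined" (no result reported)
- Compound 3 `CN1CCN(c2ccc(Nc3ncc4nc(Nc5ccccc5)n([C@@H]5CCN(S(=O)(=O)C6CC6)C5)c4n3)cc2)CC1`: 200 nM

Compound 3 is the only one of these with a number, so it has no measured neighbour to be ranked against. The next compound is compound 4 `CN1CCN(c2ccc(Nc3ncc4nc(Nc5ccccc5)n([C@H]5CCN(S(=O)(=O)C6CC6)C5)c4n3)cc2)CC1`, and the change is small: the two compounds have the same atoms and bonds and differ only in configuration as drawn: 1 of 1 stereo elements differ; a stereocentre at a saturated ring carbon is drawn R in compound 3 and S in compound 4. Among the compounds with values here, no measured pair shows what such a change does in this assay, so the direction cannot be read from the data. Within the data shown here, the only anchor is compound 3 at 200 nM. The expected step of no change at the digits printed from compound 3 to compound 4 (within the scatter) is therefore none beyond the usual scatter, though a shift either way remains possible. For compound 4 the estimated value is 200 nM, with an expected range from 60 nM to 700 nM.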

Compound 4, half-maximal inhibitory concentration: 240 nM
The estimate for compound 4 lay 1.2-fold (0.08 log units) below the measured number; the range from low to high includes it.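

In this assay the first measured pair shows a 1.2-fold higher number from compound 3 to compound 4 (0.08 log units; within the scatter) and so gives no sign that this stereocentre at a saturated ring carbon matters when the cyclopropylsulfonyl group is present. The drawn R and S forms cannot be told apart by this read-out. The pair can be read directly, with a single difference between the two compounds: the fact that compounds 3 and 4 differ only in the configuration as drawn

From the compounds shown here alone, it remains open whether the two configurations would also read alike if the cyclopropylsulfonyl group were replaced by an acetyl group or a longer alkylsulfonyl chain.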